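Swapping a Fused Bicyclic Piperazine for Plain Piperazine

The compounds below may be only part of what the source reports. "The series", "measured", "known", "first", "only" and "open" are said of these compounds alone.

Compound 1 `CN(C[C@H]1Cc2c(cccc2N2CCN3CCC[C@H]3C2)CN1)[C@H]1CCCc2cccnc21`: 2.92 nM
Compound 2 `CCN(C[C@H]1Cc2c(cccc2N2CCNCC2)CN1)[C@H]1CCCc2cccnc21`: 14.8 nM
Compound 3 `CCN1CCN(c2cccc3c2C[C@H](CN(C)[C@H]2CCCc4cccnc42)NC3)CC1`: 13.8 nM

All three were tested in a functional assay on CCRF-CEM cells for antagonist activity at C-X-C chemokine receptor type 4 (Homo sapiens), read by calcium flux, with stated times of 25 min and 90 s; on this read-out higher numbers stand for weaker inhibition and lower numbers for stronger inhibition. Compound 1 gives the lowest number of the three, with compound 3 nearest and compound 2 furthest away. Compound 4 `CN(C[C@H]1Cc2c(cccc2N2CCNCC2)CN1)[C@H]1CCCc2cccnc21` is not yet measured. It differs from compound 1 at one spot: a group of 6 heavy atoms (4 carbon, 2 nitrogen; one six-membered non-aromatic ring with 2 hetero atoms) in place of a group of 9 heavy atoms (7 carbon, 2 nitrogen; one five-membered non-aromatic ring with 1 hetero atom, one six-membered non-aromatic ring with 2 hetero atoms), on an aromatic carbon. Going by the values given here, the only measured step at that aromatic carbon is a 4.7-fold higher number from compound 1 to compound 3 (0.67 log units; beyond the scatter), a modest weakening. Compound 2 also carries the piperazin-1-yl group and gives 14.8 nM, close to compound 3. A step of similar size, a 4.1-fold higher number from compound 1 to compound 4 (0.61 log units; beyond the scatter), is therefore expected. Compound 4 is estimated at 12 nM, with a range from 5 nM to 30 nM.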

Compound 4, half-maximal inhibitory concentration: 6.08 nM
Beside the measured number, compound 4's estimate is 2.0-fold (0.30 log units) above it; measured number inside the range.
By their numbers in this assay, from the lowest: compound 1; then compound 4; then compounds 3 and 2 (each within the scatter of the next).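

Piperazin-1-yl on this aromatic carbon keeps much of the activity of the larger fused group of compound 1 (a 2.1-fold higher number from compound 1 to compound 4 (0.32 log units; beyond the scatter)), though the fused group still gives the lowest number. Hydrogen in place of ethyl on the ring amine nitrogen lowers the number (a 2.3-fold lower number from compound 3 to compound 4 (0.36 log units; beyond the scatter)), so that ethyl is not needed here. Hydrogen in place of methyl on the chain carbon bound to the amine nitrogen also lowers it (a 2.4-fold lower number from compound 2 to compound 4 (0.39 log units; beyond the scatter)).

As far as these compounds go, how propyl or acetyl on the ring nitrogen would compare stays open. No measurement shown explains these steps.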